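The source may hold more compounds than are shown below. What is called first, only, known or untested is meant among the compounds shown, and "the series" means these compounds.

In a functional assay with Homo sapiens as the target (a lower number here means a stronger inhibitor, a higher number a weaker inhibitor), compound 1 `CC(C)[C@H](NC(=O)COc1cccc2ccccc12)C(=O)N[C@@H](CC(=O)O)C(=O)COc1ccc2ccccc2c1` gives 15900 nM, compound 2 `CC(C)[C@H](NC(=O)COc1cccc2ccccc12)C(=O)N[C@@H](CC(=O)O)C(=O)COc1cccc(C(F)(F)F)c1` gives 16600 nM and compound 3 `CC(C)[C@H](NC(=O)COc1cccc2ccccc12)C(=O)N[C@@H](CC(=O)O)C(=O)COc1cc(F)cc(F)c1F` gives 11200 nM, which places compound 3 level with the other two within the scatter. Compound 4 `CC(C)[C@H](NC(=O)COc1cccc2ccccc12)C(=O)N[C@@H](CC(=O)O)C(=O)COc1ccc([N+](=O)[O-])cc1F` keeps the shared core and changes one group: 2-fluoro-4-nitrophenyl in place of 2,3,5-trifluorophenyl on an oxygen on a saturated carbon. Earlier swaps at this same place were all small: a 1.0-fold higher number from compound 1 to compound 2 (0.02 log units; within the scatter), a 1.4-fold lower number from compound 1 to compound 3 (0.15 log units; within the scatter) and a 1.5-fold lower number from compound 2 to compound 3 (0.17 log units; within the scatter). Going by the values given here, no measured compound carries the new group, so the range stays wide, but no step beyond the scatter is expected in this assay, in either direction. The expected change is a 1.1-fold higher number from compound 3 to compound 4 (0.03 log units; within the scatter). For compound 4 the estimated value is 12000 nM, with an expected range from 5000 nM to 28000 nM.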

Compound 4, half-maximal inhibitory concentration: 15800 nM
Estimate against measurement, compound 4: 1.3-fold (0.12 log units) below, and the stated range covers the measured number.
By their numbers in this assay, from the lowest: compounds 3, 4, 1 and 2 (each within the scatter of the next).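

In this assay the 2-fluoro-4-nitrophenyl group carries hydrogen-bond acceptors that 2,3,5-trifluorophenyl lacks, yet the number stays level (a 1.4-fold higher number from compound 3 to compound 4 (0.15 log units; within the scatter)). The same holds against 3-(trifluoromethyl)phenyl (a 1.1-fold lower number from compound 2 to compound 4 (0.02 log units; within the scatter)) and naphthalen-2-yl (a 1.0-fold lower number from compound 1 to compound 4 (0.00 log units; within the scatter)), so the four groups on this oxygen now span a wider range of atoms with all their steps within the scatter. No measured evidence explains why this position responds so little. Still open, as far as these compounds go, is what an amine or a carboxylic acid on this ring would do, or a saturated alkyl chain in place of the ring.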